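Compound 4 in a series at the assay limit

The source may hold more compounds than are shown below. What is called first, only, known or untested is meant among the compounds shown, and "the series" means these compounds.

In an ADME assay on SH-SY5Y cells (Homo sapiens) for cytotoxicity, read by MTT assay, with a stated time of 72 h (on this read-out higher numbers stand for weaker inhibition and lower numbers for stronger inhibition), compound 1 `O=C(CN1CCN(C(=O)c2ccccc2)CC1)N1CCN(CCCc2c[nH]c3ccccc23)CC1` gives > 200000 nM as a limit of the assay. Compound 2 `Cc1ccc(C(=O)N2CCN(CC(=O)N3CCN(CCCc4c[nH]c5ccccc45)CC3)CC2)cc1` gives > 200000 nM as a limit too. Compound 3 `COc1cccc(C(=O)N2CCN(CC(=O)N3CCN(CCCc4c[nH]c5ccccc45)CC3)CC2)c1` gives > 200000 nM and this is again a limit, so compound 3 has no number of its own to start from.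

Compound 4 `O=C(CN1CCN(C(=O)c2ccccc2F)CC1)N1CCN(CCCc2c[nH]c3ccccc23)CC1` differs from compound 3 by 2-fluorophenyl in place of 3-methoxyphenyl on a carbonyl carbon with 2-fluorophenyl in place of 3-methoxyphenyl on a carbonyl carbon. The measured steps that bear on this change are a step that the two limits leave unreadable from compound 1 to compound 2 and a step that the two limits leave unreadable from compound 1 to compound 3 and a step that the two limits leave unreadable from compound 2 to compound 3 and none of them has a readable size. The series offers the limit of > 200000 nM in this assay, at which 3 of the 3 values shown sit, and nothing more. In this assay no step beyond the scatter is therefore expected, and no direction can be foreseen. The expected change is a number no higher from compound 3 to compound 4 (the limit leaves the size open) in size. For compound 4 the estimate is 200000 nM with an expected range from 100000 nM to 400000 nM and a report of only a limit is the likeliest outcome.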

Compound 4, half-maximal inhibitory concentration: 82600 nM
For compound 4 the middle estimate is 2.4-fold (0.38 log units) above the measured one; measured number below the stated range.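

In this assay the series now holds a value that is not a limit: the limit of > 200000 nM in this assay, at which 3 of the 4 values shown sit. Among these compounds, with 2-fluorophenyl on the carbonyl carbon the read-out shows an at least 2.4-fold lower number from compound 3 to compound 4 (0.38 log units; beyond the scatter) and an at least 2.4-fold lower number from compound 2 to compound 4 (0.38 log units; beyond the scatter), so a change at this place can move the number beyond the scatter, which the earlier compounds could not show, since the steps among compound 1, compound 2 and compound 3 cannot be read. A single added fluoro group is the only difference behind an at least 2.4-fold lower number from compound 1 to compound 4 (0.38 log units; beyond the scatter), so that single replacement is enough to bring the number down from the limit.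

As far as these compounds go, the full size of these steps stays open, since each starts from a limit. Whether the result is particular to fluoro also stays open, as the compounds shown include no chlorophenyl or aminophenyl on this carbonyl carbon.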